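Allylamino for diethylamino on a shared core

The source may hold more compounds than are shown below. What is called first, only, known or untested is meant among the compounds shown, and "the series" means these compounds.

Compound 3 `CCN(CC)c1n[n+]([O-])c2ccccc2[n+]1[O-]` gives > 107000 nM in a functional assay on HepG2 cells (Homo sapiens) for cytotoxicity, read by MTT assay, with a stated time of 48 h (on this read-out lower numbers stand for stronger inhibition and higher numbers for weaker inhibition), and this is a limit of the assay, not a number. That places compound 3 at the limit of > 107000 nM in this assay, at which 1 of the 3 values shown sits. Compound 1 `[O-][n+]1nc(NCc2ccccc2)[n+]([O-])c2ccccc21` gives 8200 nM, and compound 2 `CCNc1n[n+]([O-])c2ccccc2[n+]1[O-]` gives 13500 nM. Both carry a hydrogen on the nitrogen attached to the core.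

Compound 4 `C=CCNc1n[n+]([O-])c2ccccc2[n+]1[O-]` has allylamino in place of diethylamino on an aromatic carbon. This restores the hydrogen on that nitrogen, as in compound 2.

Within the data shown here, two measured steps bear on this change. The first is an at least 7.9-fold higher number from compound 2 to compound 3 (0.89 log units; beyond the scatter), where ethyl replaces that hydrogen. The second is a 1.6-fold higher number from compound 1 to compound 2 (0.22 log units; within the scatter), where methyl replaces phenyl on the chain, so the exchange of one chain for another made little difference there. Compound 4 is therefore expected to resemble compound 1 and compound 2 rather than compound 3. The expected change in this assay is a clear drop to a lower number, meaning stronger inhibition, and the estimated step is an at least 8.9-fold lower number from compound 3 to compound 4 (0.95 log units; beyond the scatter). For compound 4 the estimate is 12000 nM, with an expected range from 5000 nM to 30000 nM.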

Compound 4, half-maximal inhibitory concentration: > 56000 nM
Compound 4: only a limit was reported; the forecaster's own chance of this, stated with the estimate: 10%; middle value at least 4.6-fold (0.66 log units) away from the limit.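

Compound 4 reads as a limit of the assay, not a number, in this assay: the limit of > 56000 nM in this assay, at which 1 of the 4 values shown sits. A hydrogen on the nitrogen attached to the core therefore does not by itself bring a compound into the range of compound 1 and compound 2, since the chain on that nitrogen matters too: there is an at least 4.1-fold higher number from compound 2 to compound 4 (0.61 log units; beyond the scatter), and there is an at least 6.8-fold higher number from compound 1 to compound 4 (0.83 log units; beyond the scatter). The step between compound 3 and compound 4 cannot be read, as each of the two is reported only as a limit, so the change from diethylamino to allylamino has no measurable size here.

The compounds shown cannot tell whether the double bond of allylamino or some other feature of that chain sets compound 4 apart, and a propylamino group in the same place would bear on that question. As far as these compounds go, how far the true value of compound 4 lies beyond its limit also stays open.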